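Ether substituents on a saturated bicyclic amine: binding notes

The source may report more compounds than this note shows. Statements on the series, on what has been measured and on what is new or still open speak of the compounds shown alone.

Compound 1 `CN1CC[C@@H]2CC[C@H](OCc3ccccc3)C[C@@H]21` gives 300000 nM in an assay on HEK293 cells for displacement of a labelled ligand from Neuronal acetylcholine receptor; alpha4/beta4 (Rattus norvegicus), with a stated time of 4 h; a higher number here means a weaker inhibitor, a lower number a stronger inhibitor.
Compound 2 `CCO[C@H]1CC=C2CCN(C)[C@H]2C1` gives > 300000 nM in this assay, which is a limit of the assay and not a number.

Compound 2 stands at the ceiling of this assay (the limit of > 300000 nM in this assay, at which 1 of the 2 values shown sits); only a limit is known for it, so its true inhibition constant may lie anywhere past that ceiling. Compound 1 sits at the same order of weak binding, and nothing in the two values separates the pair beyond the usual scatter. Among the measured compounds shown here, no step between measured compounds is known, so the effect of substitution on the ether chain is not fixed by any data in hand.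

Compound 3 `COCCO[C@H]1CC=C2CCN(C)[C@H]2C1` is the next member. It differs from compound 2 by methoxy in place of hydrogen on a saturated chain carbon, two bonds along the chain from an oxygen on a saturated carbon. Since compound 2 is already at its limit > 300000 nM, the expected step from this small addition is none beyond the scatter, and the estimated step is a number no higher from compound 2 to compound 3 (the limit leaves the size open). Compound 3 is therefore expected at 300000 nM, with a range from 100000 nM to 1000000 nM, most likely reported again only as a limit.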

Compound 3, inhibition constant: > 300000 nM
Compound 3: a limit, no number (the forecaster's own chance of this, stated with the estimate: 70%); the middle value sits exactly at the limit.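

In this assay compound 3 gives > 300000 nM, a limit of the assay and not a number. Compound 2 is also known only as a limit, so no step can be read between compound 2 and compound 3: the limit of > 300000 nM in this assay, at which 2 of the 3 values shown sit.

The compounds shown leave open whether ethoxy to 2-methoxyethoxy changes binding at all.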